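The source may report more compounds than this note shows. Statements on the series, on what has been measured and on what is new or still open speak of the compounds shown alone.

In a functional assay on Caco-2 cells (Homo sapiens) for antiproliferative activity, read by MTT assay, with a stated time of 48 h (on this read-out lower numbers stand for stronger inhibition and higher numbers for weaker inhibition), compound 1 `CCn1c(C(=O)NCCCN(C)C)ccc1C(CC)(CC)c1ccc(OCCC(O)(CC)CC)c(C)c1` gives 490 nM. Compound 2 `CCn1c(C(=O)NCCN)ccc1C(CC)(CC)c1ccc(OCCC(O)(CC)CC)c(C)c1`, which has a shorter amine chain on the same amide, gives 1740 nM, and that is a 3.6-fold higher number from compound 1 to compound 2 (0.55 log units; beyond the scatter). Compound 3 `CCn1c(C(=O)Nc2ccc(OC(F)(F)F)cc2)ccc1C(CC)(CC)c1ccc(OCCC(O)(CC)CC)c(C)c1` gives > 50000 nM. This is a limit of the assay and not a number, so compound 3 has no exact place on the scale.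

Compound 4 `CCOC(=O)CN(C)C(=O)c1ccc(C(CC)(CC)c2ccc(OCCC(O)(CC)CC)c(C)c2)n1CC` is the next to be tested. Its change from compound 3 is ((ethoxycarbonyl)methyl)(methyl)amino in place of (4-(trifluoromethoxy)phenyl)amino on a carbonyl carbon.

Among the compounds with values here, no measured step makes this exact swap. The closest are two large steps that change the same amide group, namely an at least 100-fold higher number from compound 1 to compound 3 (2.00 log units; beyond the scatter) and an at least 28-fold higher number from compound 2 to compound 3 (1.45 log units; beyond the scatter). Read in reverse, they show that replacing the (4-(trifluoromethoxy)phenyl)amino group can go with a far lower number. However, the groups in those two steps are amine chains, and compound 4 carries neither of them, so only part of that gain is expected. The expected change in this assay is an at least 4.1-fold lower number from compound 3 to compound 4 (0.61 log units; beyond the scatter), towards a lower number, and a result that stays at the limit remains possible. For compound 4 the estimated value is 12000 nM, with an expected range from 2500 nM to 50000 nM.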

Compound 4, half-maximal inhibitory concentration: 30300 nM
Compound 4: the middle estimate sits 2.5-fold (0.40 log units) below what was measured; measured number inside the range.
By their numbers in this assay, from the lowest: compound 1; then compound 2; then compound 4. At a limit, above all of these: compound 3.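

Among the compounds shown, compound 4 is the one with a measured number in this assay that carries no amine chain on the amide carbonyl, and it sits well away from both amine-chain compounds: a 17-fold higher number from compound 2 to compound 4 (1.24 log units; beyond the scatter), and a 62-fold higher number from compound 1 to compound 4 (1.79 log units; beyond the scatter). Putting ((ethoxycarbonyl)methyl)(methyl)amino in place of (4-(trifluoromethoxy)phenyl)amino on this carbonyl carbon gives an at least 1.6-fold lower number from compound 3 to compound 4 (0.21 log units; that floor lies within the scatter), so losing the aromatic ring cannot be said to bring a real gain. Going by these compounds, compound 3 stands at a limit and not at a number, so only that floor can be stated and the true size of the step stays unknown: the limit of > 50000 nM in this assay, at which 1 of the 4 values shown sits.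

The step to compound 4 removes the terminal amine and the amide hydrogen together, and the compounds shown do not tell these two changes apart. A compound keeping the amide hydrogen on the same ester chain, or a dimethylamino chain on an amide without that hydrogen, would separate them, and a carboxylic acid in place of the ethyl ester would test the ester itself.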